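Adding a second fluoro to compound 3

A few compounds are considered here, and "the series" means these few. Any claim that something is new, unique, unknown or untested is made for them only; others in the source may bear on it.

Compound 1 `O=C(Nc1cccc(F)c1)c1cc(=O)[nH]c2cc(Br)ccc12`: 7300 nM
Compound 2 `O=C(Nc1cc(F)cc(F)c1)c1cc(=O)[nH]c2cc(Br)ccc12`: 11200 nM
Compound 3 `O=C(Nc1cccc(F)c1)c1cc(=O)[nH]c2cc(F)ccc12`: > 20000 nM (a limit)

In a functional assay on KYSE-410 cells (Homo sapiens) for antiproliferative activity, read by MTT assay, with a stated time of 72 h (a lower number here means a stronger inhibitor, a higher number a weaker inhibitor), compound 3 gives only a limit, > 20000 nM, and not a number. Fluoro in place of bromo on an aromatic carbon gave an at least 2.7-fold higher number from compound 1 to compound 3 (0.43 log units; beyond the scatter).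

Compound 4 `O=C(Nc1cc(F)cc(F)c1)c1cc(=O)[nH]c2cc(F)ccc12` differs from compound 3 by fluoro in place of hydrogen on an aromatic carbon, meta to a fluoro group. Among the compounds with values here, the one measured step of this kind was a 1.5-fold higher number from compound 1 to compound 2 (0.19 log units; within the scatter). No change beyond the scatter is therefore expected in this assay. The expected step is a step that the limit leaves unreadable from compound 3 to compound 4. Compound 4 is estimated at 25000 nM, with an expected range from 13000 nM to 50000 nM.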

Compound 4, half-maximal inhibitory concentration: > 20000 nM
Compound 4: only a limit was reported (the forecaster's own chance of this, stated with the estimate: 65%); the middle value does not contradict the limit.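

In this assay compound 4 gives the limit > 20000 nM and no number, so the step from compound 3 cannot be read. With the second fluoro present, fluoro in place of bromo gives an at least 1.7-fold higher number from compound 2 to compound 4 (0.25 log units; that floor lies within the scatter) and has now been read on two cores: the same change on two cores in this assay, an at least 2.7-fold higher number (0.43 log units; beyond the scatter) from compound 1 to compound 3 and an at least 1.7-fold higher number (0.25 log units; that floor lies within the scatter) from compound 2 to compound 4; the limit leaves it open whether they differ. Compound 3 and compound 4 both rest on a limit and not on a number: the limit of > 20000 nM in this assay, at which 2 of the 4 values shown sit.

On these data alone, whether the added fluoro changes anything on the core of compound 3 stays open. As far as these compounds go, what an amine or a methoxy group in place of the bromo would give in this assay also stays open.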